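The compounds below may be only part of what the source reports. "The series", "measured", "known", "first", "only" and "open" are said of these compounds alone.

Measured in a functional assay on the whole organism (stomach) with Rattus norvegicus as the target; a higher number here means that more compound is needed for the effect, a lower number that less compound is needed:
Compound 1 `CCC(=N)N1CCC(C(c2ccccc2)c2ccccc2)CC1`: 20 mg/kg
Compound 2 `C=CC/N=C/N1CCC(C(c2ccccc2)c2ccccc2)CC1`: 13.2 mg/kg
Compound 3 `CCCCCCCCCC/N=C/N1CCC(C(c2ccccc2)c2ccccc2)CC1`: 43.1 mg/kg

Compound 3 has the highest number of the three, at 43.1 mg/kg. Compound 4 `CCCCCCC/N=C/N1CCC(C(c2ccccc2)c2ccccc2)CC1` differs from it by hydrogen in place of propyl on a saturated chain carbon, seven bonds along the chain from a double-bonded nitrogen, with hydrogen in place of propyl on a saturated chain carbon, seven bonds along the chain from a double-bonded nitrogen. The step of a 1.5-fold lower number from compound 1 to compound 2 (0.18 log units; within the scatter) lies within the scatter and offers little guidance here. The more relevant evidence is a 3.3-fold higher number from compound 2 to compound 3 (0.51 log units; beyond the scatter), a modest step with nonyl in place of vinyl. Given that step, a smaller move toward a lower number is expected in this assay. The expected step is a 1.7-fold lower number from compound 3 to compound 4 (0.24 log units; within the scatter). For compound 4 the estimated value is 25 mg/kg, with an expected range of 12 mg/kg to 50 mg/kg.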

Compound 4, dose for half-maximal effect: 33.4 mg/kg
Beside the measured number, compound 4's estimate is 1.3-fold (0.13 log units) below it; the measured number falls inside the stated range.
By their numbers in this assay, from the lowest: compounds 2, 1, 4 and 3 (each within the scatter of the next, the first and the last beyond it).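

In this assay, hydrogen in place of propyl on a saturated chain carbon, seven bonds along the chain from a double-bonded nitrogen, gives a 1.3-fold lower number from compound 3 to compound 4 (0.11 log units; within the scatter), so this change does not separate the two compounds. Hexyl in place of vinyl still gives a 2.5-fold higher number from compound 2 to compound 4 (0.40 log units; beyond the scatter), so a gap remains even with the shorter chain, while the group change on the amine nitrogen gives a 1.7-fold higher number from compound 1 to compound 4 (0.22 log units; within the scatter). No evidence is available to account for these numbers.

As far as these compounds go, whether butyl, or a chain carrying an amine or a carboxylic acid, in place of hexyl would come closer to compound 2 stays open.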